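The compounds below may be only part of what the source reports. "The series", "measured", "known", "first", "only" and "open" are said of these compounds alone.

Measured so far in an assay on isolated protein for inhibition of protein kinase C theta type (Homo sapiens), read by TR-FRET, with a stated time of 2 h; a higher number here means a weaker inhibitor, a lower number a stronger inhibitor:
Compound 1 `N#Cc1cnc(NCc2ccccc2C(F)(F)F)cc1N[C@H]1CC[C@@H](O)CC1` gives 140 nM.
Compound 2 `N#Cc1cnc(NCc2cnccc2C(F)(F)F)cc1N[C@H]1CC[C@H](O)CC1` gives 350 nM.
Compound 3 `N#Cc1cnc(NCc2ccccc2C(F)(F)F)cc1N[C@H]1C[C@@H](C(N)=O)C1` gives 150 nM.

Compound 2 stands at the highest number of the three, beyond the scatter from compound 3 and from compound 1, so it is the weakest inhibitor among these. Compound 4 `N#Cc1cnc(NCc2cnccc2C(F)(F)F)cc1N[C@H]1CC[C@@H](C(N)=O)CC1` has not yet been measured. Its change from compound 2 is 4-carbamoylcyclohexyl in place of 4-hydroxycyclohexyl on a nitrogen on an aromatic ring. Among the compounds with values here, one measured step bears on this kind of swap: a 1.1-fold higher number from compound 1 to compound 3 (0.03 log units; within the scatter). There the group that enters is a 3-carbamoylcyclobutyl rather than a 4-carbamoylcyclohexyl, so the ring is not the same, but in both cases a hydroxyl gives way to a carbamoyl, and in that step the number hardly moved. Compound 4 is therefore expected to stay close to compound 2, with an expected step of no change at the digits printed from compound 2 to compound 4 (within the scatter) in this assay, no direction beyond the scatter being predicted. Compound 4 is estimated at 350 nM, in the range 150 nM to 800 nM.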

Compound 4, half-maximal inhibitory concentration: 7 nM
For compound 4 the middle estimate is 50-fold (1.70 log units) above the measured one; the whole stated range lies above it.
By their numbers in this assay, from the lowest: compound 4; then compounds 1 and 3 (each within the scatter of the next); then compound 2.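

In this assay the change from 4-hydroxycyclohexyl to 4-carbamoylcyclohexyl on this nitrogen gives a large gain (a 50-fold lower number from compound 2 to compound 4 (1.70 log units; beyond the scatter)), so this position can respond strongly to the group carried on its ring. The earlier swap to 3-carbamoylcyclobutyl left the number within the scatter (a 1.1-fold higher number from compound 1 to compound 3 (0.03 log units; within the scatter)), so a carbamoyl group does not bring such a gain in every setting. The data shown offer no explanation for the size of this step.

From the compounds shown here alone, it stays open whether 4-carbamoylcyclohexyl would bring the same gain on the core of compound 1, where the other substituent also differs from that of compound 4. Going by these compounds, it also stays open whether a carboxylic acid, an amine or a longer chain ending in a carbamoyl group on the cyclohexyl ring would keep the gain.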